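Removing the ring methyl from compound 1: an open question

The source may hold more compounds than are shown below. What is called first, only, known or untested is meant among the compounds shown, and "the series" means these compounds.

Measured compounds:
compound 1 `CCCCc1ccc(S(=O)(=O)Nc2ccc3c(c2)CCN(C)CC3)cc1` — 1.26 nM
compound 2 `Cc1ccc(-c2ccc(S(=O)(=O)Nc3ccc4c(c3)CCN(C)CC4)cc2)s1` — 6.31 nM

In an assay on isolated protein for displacement of a labelled ligand from 5-hydroxytryptamine receptor 6 (Homo sapiens), read by radioligand binding (a higher number here means a weaker inhibitor, a lower number a stronger inhibitor), compound 1 gives 1.26 nM, the lowest of the two numbers recorded; its nearest neighbour is compound 2, and the step between them is a 5.0-fold higher number from compound 1 to compound 2 (0.70 log units; beyond the scatter). That step swaps a group on the aromatic ring, so it says nothing about the part of the molecule changed next.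

Compound 3 `CCCCc1ccc(S(=O)(=O)Nc2ccc3c(c2)CCNCC3)cc1` keeps everything in compound 1 except one detail: hydrogen in place of methyl on an amine nitrogen in a ring. For the measured compounds named here, no measured pair touches that amine nitrogen in a ring, so there is no step to lean on, and the only guide is that the rest of compound 1 stays intact.

With no evidence pointing either way, compound 3 is expected to sit close to compound 1, a step of a 1.6-fold higher number from compound 1 to compound 3 (0.20 log units; within the scatter) within or near the scatter, giving an estimated 2 nM with a likely range from 0.5 nM to 8 nM.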

Compound 3, inhibition constant: 2 nM
Beside the measured number, compound 3's estimate shows no gap at the digits printed; measured number inside the range.
By their numbers in this assay, from the lowest: compounds 1 and 3 (each within the scatter of the next); then compound 2.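

The amine nitrogen in the ring now has its first direct test: in this assay, hydrogen in place of methyl gives a 1.6-fold higher number from compound 1 to compound 3 (0.20 log units; within the scatter) and so stays within the scatter. For this one pair, then, the methyl on that nitrogen can be removed without a clear change in the number, something the earlier step on the aromatic carbon could not show. Nothing shown here gives a reason for this result.

On these data alone, it remains open how a group larger than methyl on this nitrogen, such as ethyl, a longer chain or an acetyl group, would read in this assay. Compound 1 and compound 3 both carry the butyl group, so it is also unknown whether the same swap would give a similar result with the 5-methylthiophen-2-yl group of compound 2.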